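Cyclopropyl for ethyl on the imidazole nitrogen of the core

The source may hold more compounds than are shown below. What is called first, only, known or untested is meant among the compounds shown, and "the series" means these compounds.

Measured so far:
compound 1 `CN(C)c1ncnc2c1ncn2Cc1cccc(F)c1` gives 6 mg/kg
compound 2 `CCn1cnc2c(N(C)C)ncnc21` gives 15 mg/kg

In a functional assay on the whole organism for antagonist activity, with Rattus norvegicus as the target (a lower number here means that less compound is needed, a higher number that more compound is needed for the effect), compound 2 has the higher of the two numbers; its gap to compound 1 lies beyond the usual scatter. Compound 3 `CN(C)c1ncnc2c1ncn2C1CC1` is not yet measured. It differs from compound 2 by cyclopropyl in place of ethyl on an aromatic nitrogen. Going by the values given here, with no measured pair showing this change, the step from compound 2 to compound 3 is expected to stay within the scatter, in either direction. The dose for half-maximal effect of compound 3 is estimated at 12 mg/kg, with a range of 5 mg/kg to 30 mg/kg, meaning an expected step of a 1.3-fold lower number from compound 2 to compound 3 (0.10 log units; within the scatter).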

Compound 3, dose for half-maximal effect: 9 mg/kg
The estimate for compound 3 lay 1.3-fold (0.12 log units) above the measured number; the range from low to high includes it.
By their numbers in this assay, from the lowest: compounds 1, 3 and 2 (each within the scatter of the next, the first and the last beyond it).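

Cyclopropyl in place of ethyl on the aromatic nitrogen gives a 1.7-fold lower number from compound 2 to compound 3 (0.22 log units; within the scatter) in this assay and so stays within the scatter. This first matched pair at this position shows that a three-membered ring of carbon can take the place of the open ethyl chain without a step that can be told from the scatter. Nothing measured bears on the reason for this result. From the compounds shown here alone, a longer chain such as butyl on this nitrogen remains open, as does a chain carrying an amine or a carboxylic acid. One pair cannot show how far this tolerance extends.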